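The source may hold more compounds than are shown below. What is called first, only, known or untested is meant among the compounds shown, and "the series" means these compounds.

In a functional assay on Hep 3B2 cells (Homo sapiens) for antiproliferative activity, read by MTT assay, with a stated time of 24 h (a lower number here means a stronger inhibitor, a higher number a weaker inhibitor), three compounds sharing one core have been measured. Compound 1 (`Cc1ccc2nc(C(=O)Nc3c(F)cc(-c4cccc(F)c4)cc3F)c(C)c(O)c2c1`) gives > 100000 nM, which is a limit of the assay and not a number. Compound 2 (`CCc1ccc2nc(C(=O)Nc3c(F)cc(-c4cccc(F)c4)cc3F)c(C)c(O)c2c1`) gives 15800 nM. Compound 3 (`Cc1ccc2nc(C(=O)Nc3c(F)cc(-c4cccc(F)c4)cc3F)c(C)c(C(=O)O)c2c1`) gives 31600 nM. The values of compound 2 and compound 3 lie within the scatter of each other, so compound 3 stands level with compound 2.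

The next compound, compound 4 (`CCc1ccc2nc(C(=O)Nc3c(F)cc(-c4cccc(F)c4)cc3F)c(C)c(C(=O)O)c2c1`), differs from compound 3 by methyl in place of hydrogen on a saturated chain carbon bound to an aromatic carbon. This is methyl in place of hydrogen on a saturated chain carbon bound to an aromatic carbon, or methyl to ethyl when cut one bond further out.

The same change has been measured once, where the core carries hydroxy rather than carboxy, and it gave an at least 6.3-fold lower number from compound 1 to compound 2 (0.80 log units; beyond the scatter). From the compounds shown here alone, that step starts from a limit, so its full size is unknown. The replacement of hydroxy by carboxy gave an at least 3.1-fold lower number from compound 1 to compound 3 (0.50 log units; beyond the scatter), and whether these two steps add has not been tested. A modest step toward a lower number, beyond the scatter, is therefore expected in this assay.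

The expected change is a 4.0-fold lower number from compound 3 to compound 4 (0.60 log units; beyond the scatter). Compound 4 is estimated at 8000 nM, with an expected range from 2000 nM to 30000 nM.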

Compound 4, half-maximal inhibitory concentration: 16900 nM
Beside the measured number, compound 4's estimate is 2.1-fold (0.32 log units) below it; low and high end bracket the measured number.
By their numbers in this assay, from the lowest: compounds 2, 4 and 3 (each within the scatter of the next). At a limit, above all of these: compound 1.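

In this assay, methyl in place of hydrogen on a saturated chain carbon bound to an aromatic carbon gives a 1.9-fold lower number from compound 3 to compound 4 (0.27 log units; within the scatter) on the core carrying carboxy, so the step seen beyond the scatter on the core carrying hydroxy does not recur at that size: the same change on two cores in this assay, an at least 6.3-fold lower number (0.80 log units; beyond the scatter) from compound 1 to compound 2 and a 1.9-fold lower number (0.27 log units; within the scatter) from compound 3 to compound 4, at least 3.3-fold (0.52 log units) apart, beyond the scatter of two such steps Carboxy in place of hydroxy on an aromatic carbon likewise gives a 1.1-fold higher number from compound 2 to compound 4 (0.03 log units; within the scatter) once the ethyl group is present, so the two changes do not add here, and compounds 2, 3 and 4 stand level: the same change on two cores in this assay, an at least 3.1-fold lower number (0.50 log units; beyond the scatter) from compound 1 to compound 3 and a 1.1-fold higher number (0.03 log units; within the scatter) from compound 2 to compound 4, at least 3.3-fold (0.52 log units) apart, beyond the scatter of two such steps Both larger steps start from compound 1, whose > 100000 nM is a limit of the assay and not a number, so their full size remains unknown: the limit of > 100000 nM in this assay, at which 1 of the 4 values shown sits.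

The compounds shown leave open whether a longer chain, such as propyl, in place of the ethyl group would move the number beyond the scatter of this level group. They also leave open whether an amine or a methyl ester in place of the carboxy group would do so, and whether the lack of addition would hold for such groups.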